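Dropping the Chloro Atom from Compound 1

The source may hold more compounds than are shown below. What is called first, only, known or untested is meant among the compounds shown, and "the series" means these compounds.

Of the compounds shown here, three have been measured in a functional assay on MCF7 cells (Homo sapiens) for cytotoxicity, read by MTT assay, with a stated time of 72 h; on this read-out lower numbers stand for stronger inhibition and higher numbers for weaker inhibition. Compound 1 `Cc1cc(S(=O)(=O)/N=C(\N)n2nccc2-c2ccccc2)c(SCc2ccc(Cl)cc2)cc1Cl` gives 75000 nM in this assay, the second highest of the three numbers. Compound 2 `Cc1cc(-c2ccccc2)n(/C(N)=N/S(=O)(=O)c2cc(C)c(Cl)cc2SCc2ccccc2C(F)(F)F)n1` gives 101000 nM, within the scatter of compound 1, and compound 3 `Cc1cc(-c2ccccc2)n(/C(N)=N/S(=O)(=O)c2cc(C)c(Cl)cc2SCc2cccc(Cl)c2)n1` gives 25000 nM, a lower number than compound 1 beyond the scatter. For the measured compounds named here, the only step between measured compounds that differ in one place, a 4.0-fold lower number from compound 2 to compound 3 (0.61 log units; beyond the scatter), alters the aryl group on the saturated chain carbon bound to a sulfur, the same part of the molecule changed here. Compound 4 `Cc1cc(S(=O)(=O)/N=C(\N)n2nccc2-c2ccccc2)c(SCc2ccccc2)cc1Cl` differs from compound 1 by hydrogen in place of chloro on an aromatic carbon, a change at that benzyl group. That step shows that swapping substituents on this ring moves the number only modestly, and it gives no direction for removing a chloro altogether, so no step beyond the scatter is expected. Compound 4 is therefore estimated at 90000 nM, with a range from 40000 nM to 200000 nM. The expected step is a 1.2-fold higher number from compound 1 to compound 4 (0.08 log units; within the scatter).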

Compound 4, half-maximal inhibitory concentration: 20000 nM
The estimate for compound 4 lay 4.5-fold (0.65 log units) above the measured number, outside the stated range (below it).
By their numbers in this assay, from the lowest: compounds 4 and 3 (each within the scatter of the next); then compounds 1 and 2 (each within the scatter of the next).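

Hydrogen in place of chloro on this aromatic carbon, para to a large group, gave a 3.8-fold lower number from compound 1 to compound 4 (0.57 log units; beyond the scatter) in this assay, so this position responds to plain removal of the substituent and not only to swapping one substituent for another. The earlier step, a 4.0-fold lower number from compound 2 to compound 3 (0.61 log units; beyond the scatter), compared two substituted rings and gave no direction for removal; this pair supplies one, with benzylsulfanyl giving the lower number and (4-chlorobenzyl)sulfanyl the higher. Nothing available bears on why the number moved.

The compounds shown leave open whether another group at this position, such as a methoxy group or an amine, would lower the number further or raise it again. They also leave open whether removing the chloro from the 3-chlorophenyl group would give a step of similar size.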